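This account rests on a few compounds, and the source may have more. Where it says the series, first, only, none or still open, it means among the compounds named here.

In an ADME assay on cells (Macrophage, Mus musculus) for cytotoxicity, read by resazurin assay, with a stated time of 3 days (a lower number here means a stronger inhibitor, a higher number a weaker inhibitor), three compounds have been measured so far:

compound 1 `O=C(Nc1ccc(F)c(C(F)(F)F)c1)c1cc(Cl)ccc1O`: 5300 nM
compound 2 `O=C(Nc1ccc(Br)c(C(F)(F)F)c1)c1cc(Cl)ccc1O`: 4500 nM
compound 3 `O=C(Nc1cc(F)c(Br)c(F)c1)c1cc(Cl)ccc1O`: 4300 nM

Compound 2 and compound 1 differ in one place, (fluoro in place of bromo on an aromatic carbon), and this change gave a 1.2-fold higher number from compound 2 to compound 1 (0.07 log units; within the scatter). Compound 3 and compound 2 differ in more than that; the difference between the two cores is not broken down here, and the values of compound 3, compound 2 and compound 1 all lie within the scatter of one another.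

Compound 4 `O=C(Nc1cc(F)c(F)c(F)c1)c1cc(Cl)ccc1O` has not yet been measured in this assay. It differs from compound 3 by fluoro in place of bromo on an aromatic carbon, the same kind of change as that from compound 2 to compound 1, though not the same: in the earlier pair the place was ortho to a trifluoromethyl group, here it is ortho to two fluoro groups.

Because the earlier change gave a 1.2-fold higher number from compound 2 to compound 1 (0.07 log units; within the scatter), the step from compound 3 to compound 4 in this assay is expected to be similarly small, a 1.2-fold higher number from compound 3 to compound 4 (0.07 log units; within the scatter). Compound 4 is therefore estimated at 5000 nM, most likely between 2500 nM and 10000 nM.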

Compound 4, half-maximal inhibitory concentration: 4700 nM
Estimate against measurement, compound 4: 1.1-fold (0.03 log units) above; the measured number falls inside the stated range.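

In this assay, the swap of bromo for fluoro on an aromatic carbon gave a 1.1-fold higher number from compound 3 to compound 4 (0.04 log units; within the scatter), and it reads alike on the two cores: the same change on two cores in this assay, a 1.2-fold higher number (0.07 log units; within the scatter) from compound 2 to compound 1 and a 1.1-fold higher number (0.04 log units; within the scatter) from compound 3 to compound 4, 1.1-fold (0.03 log units) apart, within the scatter of two such steps. In this series, then, the change carried from one core to the other with no difference in size that can be told from scatter. Both steps lie within the scatter, however, so the pair shows no measurable effect of the change itself, and two cores do not establish that it would carry to others.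

The compounds shown leave open how this read-out responds to a non-halogen group at that place, such as an amine, a nitrile or a carboxylic acid. They also leave open whether such a group would carry across the two cores as this swap did.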